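From 2-nitrophenyl to 4-chlorophenyl on a sulfonyl sulfur

A few compounds are considered here, and "the series" means these few. Any claim that something is new, unique, unknown or untested is made for them only; others in the source may bear on it.

In an ADME assay on HEK-293T cells (Homo sapiens) for inhibition, read by CCK-8 assay, with a stated time of 48 h, tested at 20 uM (on this read-out higher numbers stand for more inhibition of growth at the one concentration tested and lower numbers for less inhibition of growth), compound 3 `N#C/C(=C\c1ccccc1OS(=O)(=O)c1ccccc1[N+](=O)[O-])C(=O)Nc1nnc(Cc2ccc(F)cc2)s1` gives 6%. Compound 2 `N#C/C(=C\c1ccccc1OS(=O)(=O)c1ccc([N+](=O)[O-])cc1)C(=O)Nc1nnc(Cc2ccc(F)cc2)s1` gives 8%, within the scatter of compound 3, while compound 1 `N#C/C(=C\c1ccccc1OS(=O)(=O)c1ccc(Cl)cc1)C(=O)Nc1nnc(Cc2ccccc2)s1` gives 25%, beyond the scatter of both.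

The compound still to be measured, compound 4 `N#C/C(=C\c1ccccc1OS(=O)(=O)c1ccc(Cl)cc1)C(=O)Nc1nnc(Cc2ccc(F)cc2)s1`, carries 4-chlorophenyl in place of 2-nitrophenyl on a sulfonyl sulfur.

For the measured compounds named here, only one measured step compares compounds differing in a single place: a number 2 percentage points lower from compound 2 to compound 3 (within the scatter). It swaps one nitrophenyl for another, so it bears only loosely on this change, and it shows little movement. Compound 1 also carries 4-chlorophenyl, but the rest of its structure is slightly different, so its 25% serves only as a rough upper guide.

No step beyond the scatter is therefore expected, though the direction is more likely upward, with an estimated a number 8 percentage points higher from compound 3 to compound 4 (within the scatter). In this assay, the estimate for compound 4 is 14%, with an expected range of 3% to 30%.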

Compound 4, percent growth inhibition at one concentration: 6%
Compound 4: the middle estimate sits 8 percentage points above what was measured; the measured number falls inside the stated range.
By their numbers in this assay, from the lowest: compounds 3, 4 and 2 (each within the scatter of the next); then compound 1.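

In this assay, changing the group on the sulfonyl sulfur does not move the read-out when the rest of the structure is held fixed: there is no change at the digits printed from compound 3 to compound 4 (within the scatter), and also a number 2 percentage points lower from compound 2 to compound 4 (within the scatter), so 4-chlorophenyl cannot be told apart from either nitrophenyl here. For the compounds shown here, the one single-place step beyond the scatter lies elsewhere, with fluoro in place of hydrogen on an aromatic carbon, and it is a number 19 percentage points lower from compound 1 to compound 4 (beyond the scatter). No measurement available here bears on the cause of either result.

As far as these compounds go, it remains open whether a group of another kind on the ring at the sulfonyl sulfur, such as an amine or a carboxylic acid, would shift the number. Going by these compounds alone, the fluoro step is seen only with 4-chlorophenyl on the sulfonyl sulfur, and whether it holds with a nitrophenyl there is also unknown.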